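A few compounds are considered here, and "the series" means these few. Any claim that something is new, unique, unknown or untested is made for them only; others in the source may bear on it.

Measured compounds:
- Compound 1 `O=c1[nH]c(=O)n(CCC(CO)CO)cc1-c1ccco1`. In a functional assay on MCF7 cells (Homo sapiens) for antiproliferative activity, read by MTT assay, with a stated time of 72 h (a lower number here means a stronger inhibitor, a higher number a weaker inhibitor), compound 1 gives < 10 nM, which is a limit of the assay (the limit of < 10 nM in this assay, at which 1 of the 3 values shown sits).
- Compound 2 `O=c1[nH]c(=O)n(CCC(CO)CO)cc1-c1cccs1` gives 6000 nM in this assay.
- Compound 3 `O=c1[nH]c(=O)n(CCC(CO)CO)cc1C#Cc1ccc(Br)cc1` gives 46000 nM in this assay.

Compound 3 stands highest of the numbers shown; compound 2 is nearest, and the only measured step, an at least 600-fold higher number from compound 1 to compound 2 (2.77 log units; beyond the scatter), concerns a change on an aromatic carbon of the core.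

Compound 4 `O=c1[nH]c(=O)n(CCC(CO)CO)cc1C#CC1CC1` differs from compound 3 by cyclopropyl in place of 4-bromophenyl on a triple-bonded carbon. Among the measured compounds shown here, no measured step bears on a change at the triple-bonded carbon, so the direction is not settled; the step of a 1.5-fold lower number from compound 3 to compound 4 (0.19 log units; within the scatter) is expected to be modest, within or near the scatter. Compound 4 is estimated at 30000 nM, range 5000 nM to 150000 nM.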

Compound 4, half-maximal inhibitory concentration: > 100000 nM
Compound 4 gave a limit, no number; the forecaster's own chance of this, stated with the estimate: 20%; at least 3.3-fold (0.52 log units) between middle value and limit.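

In this assay compound 4 gives > 100000 nM, which is a limit of the assay and not a number. Among the compounds shown here, at the triple-bonded carbon, cyclopropyl in place of 4-bromophenyl gives an at least 2.1-fold higher number from compound 3 to compound 4 (0.33 log units; beyond the scatter), the first measured change at this place, and its direction is upward. With 2-cyclopropylethynyl on the aromatic carbon, the series shows an at least 16-fold higher number from compound 2 to compound 4 (1.22 log units; beyond the scatter) and an at least 10000-fold higher number from compound 1 to compound 4 (4.00 log units; beyond the scatter), so this group stands far from both thiophen-2-yl and furan-2-yl.

On these data alone, how far compound 4 lies past its limit remains open. Also open, as far as these compounds go, is whether an amine or a longer alkyl chain on the triple-bonded carbon would lower the number.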